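Pyridazinyl Replacement in a Camphor-Derived Sulfonamide Series

This account rests on a few compounds, and the source may have more. Where it says the series, first, only, none or still open, it means among the compounds named here.

Compound 3 `CC1(C)[C@@H]2CC[C@@]1(CS(=O)(=O)N1CCN(c3ncc(C(F)(F)F)cn3)CC1)C(=O)C2` stands lowest of the two numbers in a functional assay on CHO-K1 cells for antagonist activity at C-X-C chemokine receptor type 3 (Homo sapiens), read by FLIPR and calcium flux (on this read-out lower numbers stand for stronger inhibition and higher numbers for weaker inhibition), giving 316 nM. Compound 1 `CC1(C)[C@@H]2CC[C@@]1(CS(=O)(=O)N1CCN(c3ccc(Br)cn3)CC1)C(=O)C2` gives 1580 nM, so that a 5.0-fold lower number from compound 1 to compound 3 (0.70 log units; beyond the scatter). Compound 2 `CC1(C)[C@@H]2CC[C@@]1(CS(=O)(=O)N1CCN(c3ccc(C#N)cn3)CC1)C(=O)C2` reaches only the assay limit, > 31600 nM, which is a limit and not a number. Compound 4 `CC1(C)[C@@H]2CC[C@@]1(CS(=O)(=O)N1CCN(c3ccc(C(F)(F)F)nn3)CC1)C(=O)C2` differs from compound 3 by 6-(trifluoromethyl)pyridazin-3-yl in place of 5-(trifluoromethyl)pyrimidin-2-yl on an amine nitrogen in a ring. For the measured compounds named here, no measured step moves a ring nitrogen alone; the nearest guides are the modest 5.0-fold lower number from compound 1 to compound 3 (0.70 log units; beyond the scatter) and the large at least 100-fold lower number from compound 2 to compound 3 (2.00 log units; beyond the scatter), both of which also exchange the substituent. With the trifluoromethyl retained, a step of modest size is expected, more likely toward a higher number. Compound 4 is therefore estimated at 800 nM, with a range from 250 nM to 2500 nM, which corresponds to an expected 2.5-fold higher number from compound 3 to compound 4 (0.40 log units; beyond the scatter).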

Compound 4, half-maximal inhibitory concentration: 5010 nM
Estimate against measurement, compound 4: 6.3-fold (0.80 log units) below; measured number outside the range, above it.
By their numbers in this assay, from the lowest: compound 3; then compound 1; then compound 4. At a limit, above all of these: compound 2.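

For the compounds shown here, with the trifluoromethyl kept and the counted atoms unchanged, the exchange of rings alone moves the result by a large step (a 16-fold higher number from compound 3 to compound 4 (1.20 log units; beyond the scatter)), so the arrangement of the ring itself matters here, which the earlier steps could not separate from the substituent. Trifluoromethyl alone therefore does not secure the better numbers, as the pyridazine also falls behind the bromopyridine (a 3.2-fold higher number from compound 1 to compound 4 (0.50 log units; beyond the scatter)). Compound 2 stands at a limit and not a number, so its step (an at least 6.3-fold lower number from compound 2 to compound 4 (0.79 log units; beyond the scatter)) gives only a bound: (the limit of > 31600 nM in this assay, at which 1 of the 4 values shown sits).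

Why the pyrimidine outperforms the pyridazine stays open. So does how a pyrazine ring or a methoxy group in place of trifluoromethyl would read.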